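This account rests on a few compounds, and the source may have more. Where it says the series, first, only, none or still open, it means among the compounds named here.

Three related compounds have been tested in a physicochemical assay for solubility, in phosphate buffer, with a stated time of 2 h, at pH 7.4; on this read-out lower numbers stand for lower solubility and higher numbers for higher solubility: compound 1 `FC(F)(F)c1ccc(-c2csc(Nc3ccc(Cl)cn3)n2)nc1`, compound 2 `Clc1ccc(Nc2nc(-c3ccccn3)c(Cl)s2)nc1` and compound 3 `COc1ccc(-c2nc(Nc3ccc(Cl)cn3)sc2Cl)nc1`. Compound 1, which also carries trifluoromethyl, gives < 10000 nM, a limit of the assay and not a number. Compound 2 gives < 10000 nM, again a limit. Going by these compounds, compound 3 gives < 10000 nM, also a limit, so its exact standing is unknown.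

Compound 4 `FC(F)(F)c1ccc(-c2nc(Nc3ccc(Cl)cn3)sc2Cl)nc1` differs from compound 3 in one place: trifluoromethyl in place of methoxy on an aromatic carbon. In words, this is trifluoromethyl in place of methoxy on an aromatic carbon of a six-membered aromatic ring with 1 nitrogen, two atoms from the ring nitrogen.

Going by the values given here, only one measured single change bears on this place. Methoxy in place of hydrogen on an aromatic carbon is a step that the two limits leave unreadable from compound 2 to compound 3, so it offers no size to carry over. For compound 4, no step beyond the scatter is expected in this assay, and no direction can be named, because of the limit of < 10000 nM in this assay, at which 3 of the 3 values shown sit. The estimated step is a step that the limit leaves unreadable from compound 3 to compound 4. Compound 4 is expected at about 4000 nM, within an estimated range from 800 nM to 10000 nM, and it will most likely return only a limit as well.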

Compound 4, solubility: < 10000 nM
Compound 4 gave a limit, no number; the forecaster's own chance of this, stated with the estimate: 85%; the middle value is on the limit's open side.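

In this assay compound 4 gives < 10000 nM, a limit of the assay and not a number. No step from compound 1, compound 2 or compound 3 to compound 4 can be read, because the comparison rests only on limits: the limit of < 10000 nM in this assay, at which 4 of the 4 values shown sit.

Going by these compounds, what stays open is the actual solubility of these four compounds and whether any of the changes among them makes a difference.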